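Swapping methoxy for fluoro on the aromatic ring

The compounds below may be only part of what the source reports. "The series", "measured", "known", "first", "only" and "open" are said of these compounds alone.

In a physicochemical assay for lipophilicity, read by mass spectrometry (on this read-out higher numbers stand for higher lipophilicity and lower numbers for lower lipophilicity), compound 1 `CCc1ccc(NC(=O)C2Cc3cc(OC)c(OC)cc3C2=O)cc1` gives 3.11, compound 2 `COc1ccc(NC(=O)C2Cc3cc(OC)c(OC)cc3C2=O)cc1` gives 2.08 and compound 3 `COc1ccccc1NC(=O)C1Cc2cc(OC)c(OC)cc2C1=O` gives 2.08. Among the compounds with values here, compound 3 therefore stands level with compound 2, and these two share the lowest number so far. Compound 4 `COc1cc2c(cc1OC)C(=O)C(C(=O)Nc1ccccc1F)C2` carries fluoro in place of methoxy on an aromatic carbon. Two measured steps were large, a number 1.03 log units lower from compound 1 to compound 2 (beyond the scatter) and a number 1.03 log units lower from compound 1 to compound 3 (beyond the scatter), but both removed 4-ethylphenyl, which plays no part here. Changing 4-methoxyphenyl to 2-methoxyphenyl gave no change at the digits printed from compound 2 to compound 3 (within the scatter). Within the data shown here, no measured compound carries fluoro, so the guidance is thin. A small rise within the scatter is expected, a number 0.17 log units higher from compound 3 to compound 4 (within the scatter). Compound 4 is estimated at 2.25, with an expected range of 1.85 to 2.7.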

Compound 4, partition coefficient: 2.36
Beside the measured number, compound 4's estimate is 0.11 log units below it; the measured number falls inside the stated range.
By their numbers in this assay, from the lowest: compounds 2, 3 and 4 (each within the scatter of the next); then compound 1.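

In this assay, fluoro on this aromatic carbon, ortho to a large group, reads much like methoxy (a number 0.28 log units higher from compound 3 to compound 4 (within the scatter)), and 2-fluorophenyl likewise stays within the scatter of 4-methoxyphenyl (a number 0.28 log units higher from compound 2 to compound 4 (within the scatter)). The 4-ethylphenyl compound remains apart from this fluoro compound (a number 0.75 log units lower from compound 1 to compound 4 (beyond the scatter)). Nothing available explains why fluoro and methoxy read alike here. Still open, on these data alone, is how chloro or trifluoromethyl would read at this same place, and whether an amine or a carboxylic acid there would stay level with compound 4 or move away from it.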